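A few compounds are considered here, and "the series" means these few. Any claim that something is new, unique, unknown or untested is made for them only; others in the source may bear on it.

Measured so far in an ADME assay on BaF3 cells (Mus musculus) for cytotoxicity; on this read-out higher numbers stand for an effect only at larger amounts of compound and lower numbers for an effect already at smaller amounts:

- compound 1, `CC(C)(C)n1ncc2c(Nc3ccc(OC(F)(F)F)cc3)ncnc21`: compound 1 gives 7300 nM.
- compound 2, `FC(F)(F)Oc1ccc(Nc2cc(-c3cn[nH]c3)ncn2)cc1`: compound 2 is reported only as the limit > 10000 nM.
- compound 3, `CCNC(=O)c1cc2c(Nc3ccc(OC(F)(F)F)cc3)ncnc2s1`: compound 3 is reported only as the limit > 10000 nM.

Compound 3 therefore does not stand on a number at all; its value in this assay is the limit of the read-out, and two of the three values shown sit at that same limit (the limit of > 10000 nM in this assay, at which 2 of the 3 values shown sit). Only compound 1 gives an actual number, and it lies within a factor of the limit that is not far from the scatter. For the measured compounds named here, no step between two measured compounds can be read from these data, since no two of them differ in one place.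

Compound 4, `O=C(NCCO)c1cc2c(Nc3ccc(OC(F)(F)F)cc3)ncnc2s1`, is the next compound for this assay. It differs from compound 3 by hydroxy in place of hydrogen on a saturated chain carbon, two bonds along the chain from an amide-type nitrogen. The amide part of the core and the anilino substituent are unchanged. With compound 3 at the limit and nothing in the series pointing the other way, the step from compound 3 to compound 4 is expected to be none beyond the scatter, a step that the limit leaves unreadable from compound 3 to compound 4, and most likely to end again at the limit. For compound 4 the estimate in this assay is 15000 nM, with a range from 6000 nM to 40000 nM.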

Compound 4, half-maximal effective concentration: > 10000 nM
Compound 4: no number, only a limit; the forecaster's own chance of this, stated with the estimate: 75%; the middle value does not contradict the limit.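

For the compounds shown here, compound 4 is reported in this assay only as the limit > 10000 nM and compound 3 also stands on a limit, so no step from compound 3 to compound 4 can be read. The compounds shown leave open whether hydroxy in place of hydrogen on the ethyl chain changes the read-out at all, and how compounds at the limit rank: the limit of > 10000 nM in this assay, at which 3 of the 4 values shown sit.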